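Repeating a Methyl-to-Hydrogen Change on a Second Core

The compounds below may be only part of what the source reports. "The series", "measured", "known", "first", "only" and "open" are said of these compounds alone.

Of the compounds shown here, three have so far been measured in a functional assay on M14 cells (Homo sapiens) for inhibition, read by sulforhodamine B assay, with a stated time of 48 h; on this read-out higher numbers stand for weaker inhibition of growth and lower numbers for stronger inhibition of growth. Compound 1 `O=C(Nc1cccc(-n2cc(-c3ccncc3)c(-c3ccc(Cl)c(O)c3)n2)c1)Nc1cccc(C(F)(F)F)c1` gives 1400 nM. Compound 2 `COc1cc(-c2nn(-c3cccc(NC(=O)Nc4cccc(C(F)(F)F)c4)c3)cc2-c2ccncc2)ccc1Cl` gives 754 nM, and compound 3 `COc1cc(-c2nn(-c3cccc(NC(=O)Nc4ccc(Cl)c(C(F)(F)F)c4)c3)cc2-c2ccncc2)ccc1Cl` gives 1080 nM. All three numbers lie within the usual scatter of one another, so none of them can be called more or less potent than the others on this evidence.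

Compound 1 and compound 2 differ at one place: hydrogen in place of methyl on an oxygen on an aromatic ring. This change gave a 1.9-fold higher number from compound 2 to compound 1 (0.27 log units; within the scatter). Compound 3 differs from compound 2 by chloro in place of hydrogen on an aromatic carbon, a change that gave a 1.4-fold higher number from compound 2 to compound 3 (0.16 log units; within the scatter).

Compound 4 `O=C(Nc1cccc(-n2cc(-c3ccncc3)c(-c3ccc(Cl)c(O)c3)n2)c1)Nc1ccc(Cl)c(C(F)(F)F)c1` has not yet been measured. It differs from compound 3 by hydrogen in place of methyl on an oxygen on an aromatic ring. The place of this change is described in exactly the same words as the change from compound 2 to compound 1, so it is the same change, now made on the core of compound 3 instead of the core of compound 2. Among the compounds with values here, with only one earlier example, the expectation for compound 4 is simply that the change behaves as it did before. For compound 4 the expected step is a 1.9-fold higher number from compound 3 to compound 4 (0.27 log units; within the scatter), resting on a 1.9-fold higher number from compound 2 to compound 1 (0.27 log units; within the scatter). That earlier step was itself inside the scatter. The range around the estimate is therefore kept wide. In this assay compound 4 is therefore estimated at 2000 nM, with a likely range from 900 nM to 4500 nM.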

Compound 4, concentration for 50% growth inhibition: 886 nM
Compound 4: middle estimate off by 2.3-fold (0.35 log units), on the high side, outside the stated range (below it).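

On the core of compound 3, replacing methoxy with hydroxy gave a 1.2-fold lower number from compound 3 to compound 4 (0.09 log units; within the scatter) in this assay, and this step and the earlier one on the other core do not differ measurably: the same change on two cores in this assay, a 1.9-fold higher number (0.27 log units; within the scatter) from compound 2 to compound 1 and a 1.2-fold lower number (0.09 log units; within the scatter) from compound 3 to compound 4, 2.3-fold (0.35 log units) apart, within the scatter of two such steps. The chloro change, read here on the hydroxy compounds, gave a 1.6-fold lower number from compound 1 to compound 4 (0.20 log units; within the scatter), and it also agrees with its earlier counterpart: the same change on two cores in this assay, a 1.4-fold higher number (0.16 log units; within the scatter) from compound 2 to compound 3 and a 1.6-fold lower number (0.20 log units; within the scatter) from compound 1 to compound 4, 2.3-fold (0.35 log units) apart, within the scatter of two such steps. This shows that, on these two cores, the methoxy to hydroxy step carries over without a detectable difference; it does not show that the step is the same on both, as a small real difference could still lie hidden in the scatter, and two cores are too few to support a rule for the series.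

Going by these compounds, it remains open whether a larger change at this place, such as a longer chain on the oxygen or an amine in place of the hydroxy, would move the number beyond the scatter. On these data alone, it also remains open whether the methoxy to hydroxy step would behave the same way on a core carrying a carboxylic acid in place of the trifluoromethyl group.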